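A few compounds are considered here, and "the series" means these few. Any claim that something is new, unique, unknown or untested is made for them only; others in the source may bear on it.

Values in an ADME assay on Vero cells (Chlorocebus sabaeus) for cytotoxicity, read by CellTiter-Glo, with a stated time of 72 h; a lower number here means that less compound is tolerated, a higher number that more compound is tolerated:
- compound 1 `CCNc1n[n+]([O-])c2ccccc2[n+]1[O-]`: 17 ug/mL
- compound 2 `CC(C)(C)C1CCC(Nc2n[n+]([O-])c3ccccc3[n+]2[O-])CC1`: 2.3 ug/mL
- compound 3 `CCNc1n[n+]([O-])c2cc(F)ccc2[n+]1[O-]`: 4.6 ug/mL

Compound 3 lies within the scatter of compound 2 and well under compound 1, with a 3.7-fold lower number from compound 1 to compound 3 (0.57 log units; beyond the scatter). Compound 4 `COCC(C)Nc1n[n+]([O-])c2cc(F)ccc2[n+]1[O-]` differs from compound 3 by methoxymethyl in place of hydrogen on a saturated chain carbon bound to a nitrogen on an aromatic ring and a saturated chain carbon, turning ethyl into 1-(methoxymethyl)ethyl. For the measured compounds named here, no measured step matches this change, since the one measured step is a fluoro in place of hydrogen on an aromatic carbon. Compound 1 and compound 2 carry different chain groups, and their values show that the number can shift with that group, but they give no size for this change. No shift beyond the scatter is therefore expected in this assay. The expected step is a 1.1-fold higher number from compound 3 to compound 4 (0.04 log units; within the scatter). For compound 4 the estimated value is 5 ug/mL, with an expected range of 2 ug/mL to 13 ug/mL.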

Compound 4, half-maximal cytotoxic concentration: 6.3 ug/mL
For compound 4 the middle estimate is 1.3-fold (0.10 log units) below the measured one; the measured number falls inside the stated range.
By their numbers in this assay, from the lowest: compounds 2, 3 and 4 (each within the scatter of the next, the first and the last beyond it); then compound 1.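

In this assay there is a 1.4-fold higher number from compound 3 to compound 4 (0.14 log units; within the scatter) with methoxymethyl in place of hydrogen on a saturated chain carbon bound to a nitrogen on an aromatic ring and a saturated chain carbon, so this position takes ethyl to 1-(methoxymethyl)ethyl without a shift beyond the scatter. For the compounds shown here, this is the first single step read at this position, and it rests on the fluoro-bearing core alone. No evidence on the cause of this result is at hand.

Going by these compounds, whether the same change holds on the core of compound 1 stays open. Also open, on these data alone, is how this position answers to an amine, a carboxylic acid or a longer chain.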